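An ortho methoxy added to a compound at the limit

The compounds below may be only part of what the source reports. "The series", "measured", "known", "first", "only" and "open" are said of these compounds alone.

The series shares one core, seen in compound 1 `Cc1ccc(C(=O)NCc2ccc(CNS(=O)(=O)c3ccc(C)cc3)cc2)cc1`, which in an assay on MDA-MB-231 cells for binding affinity to C-X-C chemokine receptor type 4 (Homo sapiens), read by immunofluorescence and microscopy, with stated times of 10 min and 30 min (on this read-out higher numbers stand for an effect only at larger amounts of compound and lower numbers for an effect already at smaller amounts), gives 1000 nM. Compound 2 `Cc1ccc(S(=O)(=O)NCc2ccc(CNC(=O)c3ccccc3)cc2)cc1` differs from it by hydrogen in place of methyl on an aromatic carbon. In this assay compound 2 gives > 1000 nM, which is a limit of the assay and not a number. The step of a number no lower from compound 1 to compound 2 (the limit leaves the size open) has no readable size because of the limit of > 1000 nM in this assay, at which 1 of the 3 values shown sits. Compound 3 `O=C(NCc1ccc(CNS(=O)(=O)c2ccccc2)cc1)c1ccccc1Cl` differs from compound 2 in more than one place; in this assay compound 3 gives 10 nM. Compound 4 `COc1ccccc1C(=O)NCc1ccc(CNS(=O)(=O)c2ccc(C)cc2)cc1` has not yet been measured; it differs from compound 2 by methoxy in place of hydrogen on an aromatic carbon, the new group sitting ortho to a large group. Going by the values given here, the single measured step carries no size, so nothing measured bears directly on this change. Compound 2 and compound 3 only show that a compound of this core can reach a small number in this assay. On that slender ground compound 4 is expected to show a step of an at least 3.3-fold lower number from compound 2 to compound 4 (0.52 log units; beyond the scatter), toward an effect at smaller amounts. The value of compound 4 in this assay is estimated at 300 nM, within a range from 30 nM to 3000 nM.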

Compound 4, effective concentration (reported as EC, without a stated level of effect): 100 nM
Estimate against measurement, compound 4: 3.0-fold (0.48 log units) above; measured number inside the range.
By their numbers in this assay, from the lowest: compound 3; then compound 4; then compound 1.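

In this assay, methoxy on an aromatic carbon, ortho to a large group, gives the first step from compound 2 with a readable size: an at least 10-fold lower number from compound 2 to compound 4 (1.00 log units; beyond the scatter). Compound 2 gives > 1000 nM, which is a limit of the assay and not a number, so this step has a lower bound only: the limit of > 1000 nM in this assay, at which 1 of the 4 values shown sits. The step from the methyl-bearing benzoyl side has a full size, with 2-methoxyphenyl in place of 4-methylphenyl on a carbonyl carbon: a 10-fold lower number from compound 1 to compound 4 (1.00 log units; beyond the scatter).

The compounds shown do not tell how an amine, a hydroxy group or an ethoxy group would read at this same place. They also leave open whether methoxy elsewhere on this ring would give a step of similar size.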